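The compounds below may be only part of what the source reports. "The series", "measured", "known", "first", "only" and "open" are said of these compounds alone.

Three compounds share one core and differ only in the group attached to the sulfur. Compound 1 `Cn1c(-c2ccc(NC(=O)CSc3nc4ccccc4o3)cc2)nc(-c2ccccc2)c1-c1ccccc1` gives 76.3% in a functional assay on MCF7 cells (Homo sapiens) for cytotoxicity, read by MTT assay, with a stated time of 24 h, tested at 80 ug/mL; a higher number here means a stronger effect of the compound at the concentration tested, a lower number a weaker effect. Compound 2 `Cn1c(-c2ccc(NC(=O)CSc3nc4cc(Cl)ccc4o3)cc2)nc(-c2ccccc2)c1-c1ccccc1`, which carries a chloro in place of hydrogen on an aromatic carbon, gives 69.1%; the step of a number 7.2 percentage points lower from compound 1 to compound 2 (within the scatter) stays within the scatter. Compound 3 `Cn1cnnc1SCC(=O)Nc1ccc(-c2nc(-c3ccccc3)c(-c3ccccc3)n2C)cc1`, with a 4-methyl-4H-1,2,4-triazol-3-yl in place of the 1,3-benzoxazol-2-yl on the sulfur, gives 89.3%. On these numbers compound 2 stands lowest of the three; its gap to compound 1 is within the scatter, while the step of a number 20.2 percentage points higher from compound 2 to compound 3 (beyond the scatter) lies beyond it.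

Compound 4 `Cn1nnnc1SCC(=O)Nc1ccc(-c2nc(-c3ccccc3)c(-c3ccccc3)n2C)cc1` has not been measured. Its change from compound 2 is 1-methyl-1H-tetrazol-5-yl in place of 5-chloro-1,3-benzoxazol-2-yl on a sulfur. The two measured steps that replace a 1,3-benzoxazol-2-yl or 5-chloro-1,3-benzoxazol-2-yl on the sulfur with one five-membered aromatic ring, a number 13 percentage points higher from compound 1 to compound 3 (beyond the scatter) and a number 20.2 percentage points higher from compound 2 to compound 3 (beyond the scatter), both went upward beyond the scatter. The 1-methyl-1H-tetrazol-5-yl of compound 4 is likewise one five-membered aromatic ring, so a rise of similar size is expected, a number 15.9 percentage points higher from compound 2 to compound 4 (beyond the scatter). Compound 4 is therefore estimated at 85% in this assay, with a range from 70% to 96%.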

Compound 4, a percentage reported as activity, at one concentration (the size of the read-out at that concentration, not a potency): 77.7%
Estimate against measurement, compound 4: 7.3 percentage points above; low and high end bracket the measured number.
By their numbers in this assay, from the lowest: compounds 2, 1 and 4 (each within the scatter of the next); then compound 3.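

Exchanging one five-membered aromatic ring on the sulfur for another is not a neutral change in this assay: 1-methyl-1H-tetrazol-5-yl in place of 4-methyl-4H-1,2,4-triazol-3-yl gives a number 11.6 percentage points lower from compound 3 to compound 4 (beyond the scatter) and shows that the rise seen with compound 3 does not follow from having any single such ring at this position. Against the groups with two rings, the tetrazole gives a number 8.6 percentage points higher from compound 2 to compound 4 (within the scatter) and a number 1.4 percentage points higher from compound 1 to compound 4 (within the scatter) and so cannot be told apart from either compound, even though the 1-methyl-1H-tetrazol-5-yl has only one ring where the benzoxazoles have two. Compound 3 therefore stands alone as the most active of these four at the concentration tested, and no measurement shown here explains why the two single rings differ.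

Going by these compounds, it remains open whether other groups on the sulfur, such as 1-methyl-1H-imidazol-2-yl or a plain phenyl, would match compound 3 or fall with the rest. Each read-out comes from a single concentration, so these numbers leave the potency of all four compounds unknown.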